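The source may hold more compounds than are shown below. What is called first, only, known or untested is meant among the compounds shown, and "the series" means these compounds.

Measured compounds:
Compound 1, `CC(C)(C)c1ccc(SCc2ccc(C(=O)Nc3ccccc3N)cc2)cc1`: 9.73%
Compound 2, `Cc1cc(C)cc(SCc2ccc(C(=O)Nc3ccccc3N)cc2)c1`: 40.2%

Among the measured compounds shown here, in a functional assay on HeLa cells (Homo sapiens) for inhibition, read by CCK-8 assay, with a stated time of 72 h, tested at 2 uM (a higher number here means more inhibition of growth at the concentration tested, a lower number less inhibition of growth), compound 2 gives 40.2%, the higher of the two numbers, and its only neighbour, compound 1, gives 9.73%, a gap of more than the usual scatter. Compound 3, `Nc1ccccc1NC(=O)c1ccc(CSc2ccc(Cl)cc2)cc1`, has not yet been measured in this assay. It differs from compound 2 in one place: 4-chlorophenyl in place of 3,5-dimethylphenyl on a sulfur. For the measured compounds named here, no pair of measured compounds differing in one place is available, so no measured step can be read off here. Both measured compounds carry a substituted phenyl on the sulfur, and the two values differ widely, which suggests that the substitution pattern of that ring matters, though two compounds cannot show which feature is decisive. For compound 3 the expected step of a number 18.2 percentage points lower from compound 2 to compound 3 (beyond the scatter) is a decrease, likely beyond the scatter but not to the level of compound 1. Compound 3 is therefore estimated at 22% in this assay, with a range from 5% to 45%.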

Compound 3, percent growth inhibition at one concentration: 19.2%
Beside the measured number, compound 3's estimate is 2.8 percentage points above it; measured number inside the range.
By their numbers in this assay, from the lowest: compounds 1 and 3 (each within the scatter of the next); then compound 2.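

In this assay, placing 4-chlorophenyl instead of 3,5-dimethylphenyl on the sulfur gives a number 21 percentage points lower from compound 2 to compound 3 (beyond the scatter), the first measured sign that this position, whose other sulfur neighbour is a saturated chain carbon, responds to a single change of group by more than the scatter. The second single change, chloro in place of tert-butyl on an aromatic carbon, gives a number 9.5 percentage points higher from compound 1 to compound 3 (within the scatter), so that exchange cannot be resolved in this assay even though the two groups are quite different. Read together, the two steps show that not every change on this ring registers here: one exchange of groups stands out from the scatter, and the other does not.

As far as these compounds go, whether a single methyl, a methoxy or an amine on this ring would give a number close to that of compound 2 or that of compound 3 remains open, as does the outcome of a longer chain in place of the saturated chain carbon on the sulfur. Nothing available accounts for the size of either step.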